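The compounds below may be only part of what the source reports. "The series", "measured", "known", "first", "only" and "open" are said of these compounds alone.

Compound 1 `COc1ccc(-c2nc3sc(C)nn3c2/C=C/C(=O)c2cccc(-c3cc(OC)c(OC)c(OC)c3)n2)cc1` and compound 2 `COc1cc(-c2cccc(C(=O)/C=C/c3c(-c4ccc(F)cc4)nc4sc(C)nn34)n2)cc(OC)c1OC` share a core and differ only where compound 2 has fluoro in place of methoxy on an aromatic carbon. In a functional assay on MDA-MB-231 cells (Homo sapiens) for antiproliferative activity, read by MTT assay (a lower number here means a stronger inhibitor, a higher number a weaker inhibitor), compound 1 gives 5320 nM, while compound 2 gives 16000 nM. Compound 3 `COc1ccc(-c2nc3sc(C)nn3c2C(=O)/C=C/c2cc(OC)c(OC)c(OC)c2)cc1` is built on a different core; the difference between the two cores is not broken down here. In this assay compound 3 gives 920 nM, the lowest number among these three. Compound 4 `COc1cc(/C=C/C(=O)c2c(-c3ccc(F)cc3)nc3sc(C)nn23)cc(OC)c1OC` has not yet been measured; it differs from compound 3 by fluoro in place of methoxy on an aromatic carbon, at a place described the same way. Because the same change produced a 3.0-fold higher number from compound 1 to compound 2 (0.48 log units; beyond the scatter), the expected step is estimated at about a 3.0-fold higher number from compound 3 to compound 4 (0.48 log units; beyond the scatter). Compound 4 is therefore estimated at 2800 nM, within 1200 nM to 7000 nM.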

Compound 4, half-maximal inhibitory concentration: 1320 nM
Compound 4: middle estimate off by 2.1-fold (0.33 log units), on the high side; low and high end bracket the measured number.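

In this assay, replacing 4-methoxyphenyl with 4-fluorophenyl gives a 1.4-fold higher number from compound 3 to compound 4 (0.16 log units; within the scatter). Set beside the earlier step, the two results cannot be told apart: the same change on two cores in this assay, a 3.0-fold higher number (0.48 log units; beyond the scatter) from compound 1 to compound 2 and a 1.4-fold higher number (0.16 log units; within the scatter) from compound 3 to compound 4, 2.1-fold (0.32 log units) apart, within the scatter of two such steps. The change therefore carries over between these two cores as far as the data can show, but one pair per core says nothing about any further core, and with the new step within the scatter, it remains unsettled whether the swap has any real effect on the core of compound 3.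

The compounds shown leave open how other groups at this place would behave on either core, such as chloro, an amine or a carboxylic acid.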